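Moving a hydroxyl group on a pyridine-based scaffold

The source may hold more compounds than are shown below. What is called first, only, known or untested is meant among the compounds shown, and "the series" means these compounds.

Of the compounds shown here, three built on one shared core have been tested in a functional assay on HeLa cells (Homo sapiens) for inhibition; on this read-out lower numbers stand for stronger inhibition and higher numbers for weaker inhibition. Compound 1 `Oc1ccc(-c2cc(-c3ccccc3F)cc(-c3cccc(O)c3)n2)cc1` gives 14300 nM. Compound 2 `Oc1ccc(-c2cc(-c3ccccc3F)cc(-c3ccc(O)cc3)n2)cc1`, in this assay, reaches only the limit of the measurement, > 50000 nM. For compound 3 `Oc1cccc(-c2cc(-c3cccc(OC(F)(F)F)c3)cc(-c3cccc(O)c3)n2)c1` this assay likewise reports only a limit, > 50000 nM.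

Compounds 1 and 2 differ in a single place: 4-hydroxyphenyl in place of 3-hydroxyphenyl on an aromatic carbon. This change gave an at least 3.4-fold higher number from compound 1 to compound 2 (0.54 log units; beyond the scatter), and its size is known only as a lower bound due to the limit of > 50000 nM in this assay, at which 2 of the 3 values shown sit, at which the value of compound 2 sits.

Compound 4 `Oc1ccc(-c2cc(-c3cccc(OC(F)(F)F)c3)cc(-c3cccc(O)c3)n2)cc1` has not yet been measured. It stands to compound 3 as compound 2 stands to compound 1: 4-hydroxyphenyl in place of 3-hydroxyphenyl on an aromatic carbon. The change is of the same kind, though the surroundings differ: in the pair of compound 1 and compound 2 the place is meta to a 2-fluorophenyl group and meta to a 4-hydroxyphenyl group, whereas in the pair of compound 3 and compound 4 it is meta to a 3-hydroxyphenyl group and meta to a large group. The difference between the two cores is not broken down here.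

Since compound 3 already sits at the limit in this assay, and the same kind of change weakened compound 1 to compound 2, compound 4 is expected to remain at or beyond that limit, with an expected step that the limit leaves unreadable from compound 3 to compound 4. For compound 4 the estimated value in this assay is 90000 nM, between 40000 nM and 250000 nM.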

Compound 4, half-maximal inhibitory concentration: 14100 nM
The estimate for compound 4 lay 6.4-fold (0.81 log units) above the measured number; the whole stated range lies above it.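

Swapping 3-hydroxyphenyl for 4-hydroxyphenyl at this place gave, in this assay, an at least 3.5-fold lower number from compound 3 to compound 4 (0.54 log units; beyond the scatter), so the swap that weakened inhibition on the core of compound 1 strengthened it on the core of compound 3, and its direction did not carry over: the same change on two cores in this assay, an at least 3.4-fold higher number (0.54 log units; beyond the scatter) from compound 1 to compound 2 and an at least 3.5-fold lower number (0.54 log units; beyond the scatter) from compound 3 to compound 4, at least 12-fold (1.09 log units) apart, beyond the scatter of two such steps

For these two pairs, then, the result of the swap on one core is a poor guide to its result on the other, even though the entering and leaving groups are the same in both. This does not show which difference between the two cores turns the direction around, and the true size of each step remains unknown because of the limit: the limit of > 50000 nM in this assay, at which 2 of the 4 values shown sit.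

The compounds shown leave open whether the reversal follows the 2-fluorophenyl group, the other hydroxyphenyl group, or the two together, since the two cores are not separated into single changes. They also leave open how this place in the series would respond if an amine or a carboxylic acid stood on the ring in place of the hydroxyl group.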